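Trading (methanesulfonamido)methyl for 2H-tetrazol-5-yl on a shared core

The source may hold more compounds than are shown below. What is called first, only, known or untested is meant among the compounds shown, and "the series" means these compounds.

In an ADME assay on HEp-2 cells (Homo sapiens) for cytotoxicity (a higher number here means that more compound is tolerated, a lower number that less compound is tolerated), compound 1 `CC(C)CCn1c(Cn2c(=O)n(C(C)C)c3ccccc32)nc2cc(CNS(C)(=O)=O)ccc21` gives 30800 nM and compound 2 `CC(C)CCn1c(Cn2c(=O)n(C(C)C)c3ccccc32)nc2ccc(CN(C)C)cc21` gives 26700 nM so the two stand level within the usual scatter. For the measured compounds named here, compound 1 therefore sits alongside the only other measured compound, and the pair differ in their side chains. Compound 3 `CC(C)CCn1c(Cn2c(=O)n(C(C)C)c3ccccc32)nc2cc(-c3nn[nH]n3)ccc21` keeps the core of compound 1 but carries 2H-tetrazol-5-yl in place of (methanesulfonamido)methyl on an aromatic carbon. Going by the values given here, no measured step in this assay covers this exchange, so any forecast rests on thin ground. Compound 2 at 26700 nM and compound 1 at 30800 nM show only that these two side chains give matching values, which supports no large expected move. The expected change a 1.6-fold higher number from compound 1 to compound 3 (0.21 log units; within the scatter) is a modest rise, with a wide margin. For compound 3 the estimate is 50000 nM with 20000 nM to 130000 nM as the expected range.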

Compound 3, half-maximal cytotoxic concentration: 2000 nM
Compound 3: middle estimate off by 25-fold (1.40 log units), on the high side, and the stated range ends above it.
By their numbers in this assay, from the lowest: compound 3; then compounds 2 and 1 (each within the scatter of the next).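

For the compounds shown here, the exchange of (methanesulfonamido)methyl for 2H-tetrazol-5-yl on this aromatic carbon gives the first step that can be read in this assay: a 15-fold lower number from compound 1 to compound 3 (1.19 log units; beyond the scatter). Going by these compounds alone, the step is large, so the group at this place is not neutral for how much compound the HEp-2 cells tolerate, which the earlier compounds could not show because they offered no single-place step. Nothing measured here accounts for a change of this size.

The compounds shown leave open whether the lower number belongs to the 2H-tetrazol-5-yl ring itself or to the loss of (methanesulfonamido)methyl. They also leave open whether a carboxylic acid or an amine on the same aromatic carbon would follow compound 3 or stay with compound 1.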